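The compounds below may be only part of what the source reports. "The series", "measured", "known", "first", "only" and "open" are said of these compounds alone.

Measured so far:
- compound 1 `O=C(NCc1cn(Cc2ccc(F)cc2)nn1)c1cn(-c2ccccc2)nc1-c1ccccc1`: in a functional assay on MIA PaCa-2 cells (Homo sapiens) for antiproliferative activity, read by sulforhodamine B assay, with a stated time of 48 h (on this read-out lower numbers stand for stronger inhibition of growth and higher numbers for weaker inhibition of growth), compound 1 gives 9600 nM
- compound 2 `O=C(NCc1cn(Cc2ccc(C(F)(F)F)cc2)nn1)c1cn(-c2ccccc2)nc1-c1ccccc1`: compound 2 gives 17700 nM
- compound 3 `O=C(NCc1cn(Cc2ccc(F)cc2)nn1)c1cn(-c2ccccc2)nc1-c1ccc(Cl)cc1`: compound 3 gives 1990 nM

Compound 3 holds the lowest number of the three, with both other compounds clearly separated from it; the step of a 4.8-fold lower number from compound 1 to compound 3 (0.68 log units; beyond the scatter) lies beyond the scatter, and compound 2 at 17700 nM sits further off still.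

Compound 4 `O=C(NCc1cn(Cc2ccc(C(F)(F)F)cc2)nn1)c1cn(-c2ccccc2)nc1-c1ccc(Cl)cc1` is the next step from compound 3: trifluoromethyl in place of fluoro on an aromatic carbon, the 4-fluorobenzyl becoming 4-(trifluoromethyl)benzyl while the chloro-bearing ring of compound 3 is kept. For the measured compounds named here, the only measured step that bears on this change is a 1.8-fold higher number from compound 1 to compound 2 (0.27 log units; within the scatter), the same exchange made on the shared core without the chloro, and it stayed within the scatter. The chloro step a 4.8-fold lower number from compound 1 to compound 3 (0.68 log units; beyond the scatter) is not part of this move and offers no further guide. Going by the values given here, no measured pair shows the two changes together, so whether they add up is not known here.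

On that single precedent, compound 4 is expected to move by about a 1.6-fold higher number from compound 3 to compound 4 (0.21 log units; within the scatter), a small rise at most and not beyond the scatter. The estimate for compound 4 is 3200 nM, with a range from 1300 nM to 8000 nM.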

Compound 4, concentration for 50% growth inhibition: 1100 nM
Beside the measured number, compound 4's estimate is 2.9-fold (0.46 log units) above it, outside the stated range (below it).
By their numbers in this assay, from the lowest: compounds 4 and 3 (each within the scatter of the next); then compounds 1 and 2 (each within the scatter of the next).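

In this assay, the exchange of fluoro for trifluoromethyl at this place now also stands on the chloro-bearing core, as a 1.8-fold lower number from compound 3 to compound 4 (0.26 log units; within the scatter); each step alone stays within the scatter, but the two cores do not give the same result: the same change on two cores in this assay, a 1.8-fold higher number (0.27 log units; within the scatter) from compound 1 to compound 2 and a 1.8-fold lower number (0.26 log units; within the scatter) from compound 3 to compound 4, 3.3-fold (0.52 log units) apart, beyond the scatter of two such steps

The chloro change, previously seen only with 4-fluorobenzyl, now also stands with 4-(trifluoromethyl)benzyl, as a 16-fold lower number from compound 2 to compound 4 (1.21 log units; beyond the scatter), and its size depends on which of the two groups is present: the same change on two cores in this assay, a 4.8-fold lower number (0.68 log units; beyond the scatter) from compound 1 to compound 3 and a 16-fold lower number (1.21 log units; beyond the scatter) from compound 2 to compound 4, 3.3-fold (0.52 log units) apart, beyond the scatter of two such steps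

These four compounds therefore show that the two changes do not simply add up, so a step measured for one of them on a single core is no safe guide to the same step on the other core.

The compounds shown leave open whether this dependence extends beyond fluoro and trifluoromethyl, for instance to a nitrile, a methoxy group, an amine or a carboxylic acid at the same place. They also leave open whether bromo or methyl in place of chloro would show the same dependence on the group at this place.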